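The source may report more compounds than this note shows. Statements on the series, on what has been measured and on what is new or still open speak of the compounds shown alone.

Values in a functional assay on ZR-75-1 cells (Homo sapiens) for cytotoxicity, read by MTT assay, with a stated time of 72 h; a lower number here means that less compound is needed, a higher number that more compound is needed for the effect:
- Compound 1 `CCOC(=O)c1c(C)coc1-c1ccc2c(CC)cccc2c1OC`: 3.9 ug/mL
- Compound 2 `CCCOC(=O)c1c(C)coc1-c1ccc2c(CC)cccc2c1OC`: > 10 ug/mL (a limit)
- Compound 3 `CCOCc1c(C)coc1-c1ccc2c(CC)cccc2c1OC`: 9.1 ug/mL

Only compound 1 and compound 3 have true numbers, and compound 3 holds the higher one. The step between them is a 2.3-fold higher number from compound 1 to compound 3 (0.37 log units; beyond the scatter). Compound 2 gives only a limit, so its step of an at least 1.0-fold lower number from compound 2 to compound 3 (0.04 log units; that floor lies within the scatter) says little.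

Compound 4 `CCc1cccc2c(OC)c(-c3occ(C)c3COC(=O)CCN(CC)CC)ccc12` differs from compound 3 as follows: (2-(diethylamino)ethyl)carbonyl in place of ethyl on an oxygen on a saturated carbon. The ethyl on the oxygen is thus replaced by the much larger (2-(diethylamino)ethyl)carbonyl.

Among the compounds with values here, no measured step makes this change. The closest guides are compound 3 itself and the two modest steps in the series, a 2.3-fold higher number from compound 1 to compound 3 (0.37 log units; beyond the scatter) and an at least 2.5-fold higher number from compound 1 to compound 2 (0.40 log units; beyond the scatter). They point in no single direction for a new group of this kind, so no step beyond the scatter is expected in this assay.

The expected change is a 1.5-fold lower number from compound 3 to compound 4 (0.18 log units; within the scatter). For compound 4 the estimated value is 6 ug/mL, with an expected range of 2 ug/mL to 11 ug/mL.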

Compound 4, concentration for half-maximal effect: 1.7 ug/mL
Compound 4: middle estimate off by 3.5-fold (0.55 log units), on the high side, and the stated range ends above it.
By their numbers in this assay, from the lowest: compound 4; then compound 1; then compound 3. At a limit, above all of these: compound 2.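

At this position, on an oxygen on a saturated carbon, the small ethyl of compound 3 can give way to the much larger (2-(diethylamino)ethyl)carbonyl without loss in this assay: the change gives a 5.4-fold lower number from compound 3 to compound 4 (0.73 log units; beyond the scatter). Within the data shown here, the earlier steps beyond the scatter all raised the number, so this is the first change that lowers it, and it brings in a nitrogen and a carbonyl together. The limit on compound 2 has no bearing on this result, and nothing shown gives a cause for the step.

On these data alone, whether the step rests on the diethylamino group, the new carbonyl or the added chain length remains open. A plain propanoyl group on this oxygen, a free hydroxyl, or a dimethylamino or piperidine end group would help separate these parts.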